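Phenyl in Place of Thiophen-2-yl: What to Expect

The source may report more compounds than this note shows. Statements on the series, on what has been measured and on what is new or still open speak of the compounds shown alone.

Within the data shown here, compound 1 `Cn1cccc1-c1cc(-c2cccs2)[nH]c(=O)c1C#N` is the only compound here with a number rather than a limit: in a functional assay on IGROV-1 cells (Homo sapiens) for inhibition, read by sulforhodamine B assay, with a stated time of 48 h (on this read-out lower numbers stand for stronger inhibition of growth and higher numbers for weaker inhibition of growth), compound 1 gives 22900 nM. Compound 2 `Cn1cccc1-c1cc(-c2ccccc2)nc(N)c1C#N` has a different core and reaches only > 100000 nM, which is a limit of this assay and not a number. Thus, of the two results shown, one sits at the limit (the limit of > 100000 nM in this assay, at which 1 of the 2 values shown sits), and compound 1 alone anchors the scale.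

Compound 3 `Cn1cccc1-c1cc(-c2ccccc2)[nH]c(=O)c1C#N` has not yet been measured in this assay. It differs from compound 1 by phenyl in place of thiophen-2-yl on an aromatic carbon. Among the measured compounds shown here, no measured pair in this set shows that change, so its size is unknown; a small shift toward weaker inhibition of growth, possibly within the scatter, is expected. The step of a 1.5-fold higher number from compound 1 to compound 3 (0.18 log units; within the scatter) is therefore estimated to be modest. For compound 3 the expected value in this assay is 35000 nM, within a range from 12000 nM to 100000 nM.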

Compound 3, concentration for 50% growth inhibition: > 100000 nM
Compound 3: only a limit was reported (the forecaster's own chance of this, stated with the estimate: 25%); at least 2.8-fold (0.45 log units) between middle value and limit.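

On the shared core, the place next to the ring nitrogen proves sensitive to which aromatic ring it carries: in this assay, phenyl in place of thiophen-2-yl gives an at least 4.3-fold higher number from compound 1 to compound 3 (0.64 log units; beyond the scatter). Compound 3 gives > 100000 nM, which is a limit of the assay and not a number. The step therefore has no upper bound, and the scale still rests on a single measured number, that of compound 1: the limit of > 100000 nM in this assay, at which 2 of the 3 values shown sit.

The compounds shown do not separate the loss of the sulfur atom from the change in ring size, as both change together in this one step. As far as these compounds go, whether furan-2-yl or thiophen-3-yl at this place would hold the value of compound 1 stays open, as does the effect of an amine or a longer chain on the phenyl ring.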